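The compounds below may be only part of what the source reports. "The series", "measured", "known", "first", "only" and "open" are said of these compounds alone.

Of the compounds shown here, two have been measured in an assay on HEK293 cells for inhibition of Monoacylglycerol lipase ABHD6 (Homo sapiens), read by fluorescence; a lower number here means a stronger inhibitor, a higher number a weaker inhibitor. Compound 1 `O=C(N1CCC=C[C@@H]1COCc1ccccc1)n1cc(-c2ccc(-c3ccccc3)cc2)nn1` gives 12.6 nM in this assay, and compound 2 `O=C(N1C[C@H](O)C=C[C@H]1COCc1ccccc1)n1cc(-c2ccc(-c3ccccc3)cc2)nn1` gives 316 nM. Compound 2 therefore has the higher of the two numbers, the weaker inhibitor, and its gap to compound 1 lies beyond the usual scatter, so the difference between them is real.

Compound 3 `O=C(N1C[C@@H](O)C=C[C@@H]1COCc1ccccc1)n1cc(-c2ccc(-c3ccccc3)cc2)nn1` is the mirror image of compound 2: the two compounds have the same atoms and bonds and differ only in configuration as drawn: 2 of 2 stereo elements differ (all stereocentres are inverted: mirror images); a stereocentre at a saturated ring carbon is drawn R in compound 2 and S in compound 3; a stereocentre at a saturated ring carbon is drawn S in compound 2 and R in compound 3. The hydroxyl and the benzyloxymethyl group stay where they are, only their spatial arrangement flips. Among the compounds with values here, no measured pair shows how such a flip changes the number, so the expectation for compound 3 rests on the two values above. Since compound 2 sits well above compound 1 in this assay, the mirror-image compound 3 is estimated to move toward compound 1, with a step of a 6.3-fold lower number from compound 2 to compound 3 (0.80 log units; beyond the scatter) expected. Compound 3 is expected to give about 50 nM, within a range from 8 nM to 300 nM.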

Compound 3, half-maximal inhibitory concentration: 10 nM
Compound 3: the middle estimate sits 5.0-fold (0.70 log units) above what was measured; measured number inside the range.
By their numbers in this assay, from the lowest: compounds 3 and 1 (each within the scatter of the next); then compound 2.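

In this assay, passing to the mirror image gives a 32-fold lower number from compound 2 to compound 3 (1.50 log units; beyond the scatter), the first sign that the spatial arrangement at these two stereocentres matters in this series, and that large step can be put down to arrangement alone because nothing else changes: the fact that compounds 2 and 3 differ only in the configuration as drawn

The hydroxy group can also be present with little consequence, since hydroxy in place of hydrogen on a saturated ring carbon gives a 1.3-fold lower number from compound 1 to compound 3 (0.10 log units; within the scatter). What the hydroxy group does to the number therefore depends on how it is arranged, and its presence alone does not set the number.

Which of the two stereocentres carries the effect stays open, and a compound with only one of them inverted would tell. Also open, as far as these compounds go, is whether a methoxy group or an amine in place of the hydroxy group, in the arrangement of compound 3, would keep the number where it is.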